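Dichlorophenyl for bromophenyl on a lipoic acid coumarin triazole

A few compounds are considered here, and "the series" means these few. Any claim that something is new, unique, unknown or untested is made for them only; others in the source may bear on it.

Measured so far:
compound 1, `O=C(CCCCC1CCSS1)NCc1cn(CCCCOc2ccc3cc(-c4ccc(Br)cc4)c(=O)oc3c2)nn1`, 34.2%
compound 2, `O=C(CCCCC1CCSS1)NCc1cn(CCCCOc2ccc3cc(-c4ccc(Cl)c(Cl)c4)c(=O)oc3c2)nn1`, 39.6%
compound 3, `O=C(CCCCC1CCSS1)NCc1cn(CCCCCOc2ccc3cc(-c4ccc(Br)cc4)c(=O)oc3c2)nn1`, 41.8%

In a functional assay on PC-12 cells (Rattus norvegicus) for cytotoxicity, read by MTT assay, with stated times of 3 h and 2 h, tested at 0.1 uM (a higher number here means a stronger effect of the compound at the concentration tested, a lower number a weaker effect), compound 1 gives 34.2%, and compound 2 gives 39.6%. The change between them is 3,4-dichlorophenyl in place of 4-bromophenyl on an aromatic carbon, and it made a step of a number 5.4 percentage points higher from compound 1 to compound 2 (within the scatter). The difference between the core of compound 1 and that of compound 3 is not broken down here; in this assay compound 3 gives 41.8%; all three values lie within the scatter of one another.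

Compound 4, `O=C(CCCCC1CCSS1)NCc1cn(CCCCCOc2ccc3cc(-c4ccc(Cl)c(Cl)c4)c(=O)oc3c2)nn1`, carries the same change on the core of compound 3: 3,4-dichlorophenyl in place of 4-bromophenyl on an aromatic carbon. Because the earlier step was a number 5.4 percentage points higher from compound 1 to compound 2 (within the scatter), a step of similar size, a number 4.2 percentage points higher from compound 3 to compound 4 (within the scatter), is expected here. Compound 4 is therefore estimated at 46% in this assay, between 36% and 56%.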

Compound 4, a percentage reported as activity, at one concentration (the size of the read-out at that concentration, not a potency): 39.7%
Estimate against measurement, compound 4: 6.3 percentage points above, and the stated range covers the measured number.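

In this assay, 3,4-dichlorophenyl in place of 4-bromophenyl on the core of compound 3 gave a number 2.1 percentage points lower from compound 3 to compound 4 (within the scatter). Set beside the earlier step, this one does not differ from it beyond what repeated measurement allows: the same change on two cores in this assay, a number 5.4 percentage points higher (within the scatter) from compound 1 to compound 2 and a number 2.1 percentage points lower (within the scatter) from compound 3 to compound 4, 7.5 percentage points apart, within the scatter of two such steps. The two steps are thus compatible with the change behaving alike on both cores, but they show no effect of the change on either core, and with both steps inside the scatter they cannot show that it carries over.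

The compounds shown leave open what a phenyl ring bearing an amine or a carboxylic acid would do in this place. They also leave open whether a longer chain in the linker would give a step beyond the scatter.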